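A few compounds are considered here, and "the series" means these few. Any claim that something is new, unique, unknown or untested is made for them only; others in the source may bear on it.

Compound 2, `Cc1ccccc1OCC1=NCCO1`, stands second highest of the three compounds measured in a toxicity assay on the whole organism with Rattus norvegicus as the target, at a dose of 100 mg/kg by the oral route (on this read-out higher numbers stand for a stronger effect at the one dose given and lower numbers for a weaker effect), where compound 2 gives 40%. Its nearest neighbour is compound 3, `O=[N+]([O-])c1ccccc1OCC1=NCCO1`, which in this assay gives 30%, and the two values lie within the scatter of each other. Furthest from it is compound 1, `Brc1ccccc1OCC1=NCCO1`, which in this assay gives 70%.

Compound 4, `Cc1ccc(OCC2=NCCO2)c(C)c1`, differs from compound 2 in one place: methyl in place of hydrogen on an aromatic carbon. The measured steps all exchange one group for another on the aromatic ring and do not add a group to a ring position that carries hydrogen, so none of them bears directly on this change. The step of a number 30 percentage points lower from compound 1 to compound 2 (beyond the scatter) and the step of a number 40 percentage points lower from compound 1 to compound 3 (beyond the scatter) show that a swap at the ring can move the number considerably, while a number 10 percentage points lower from compound 2 to compound 3 (within the scatter) shows that another such swap leaves it within the scatter. For the measured compounds named here, with no measured step matching the addition of a methyl group, the expected step of no change at the digits printed from compound 2 to compound 4 (within the scatter) is taken as none beyond the scatter, with a wide range. Compound 4 is therefore estimated to give 40%, with a range from 20% to 65% in this assay.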

Compound 4, a percentage reported as activity, at one dose (the size of the read-out at that dose, not a potency): 25%
Compound 4: the middle estimate sits 15 percentage points above what was measured; low and high end bracket the measured number.
By their numbers in this assay, from the lowest: compounds 4, 3 and 2 (each within the scatter of the next, the first and the last beyond it); then compound 1.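

In this assay, the addition of one methyl group on an aromatic carbon, meta to a methyl group and para to a group of 7 heavy atoms, gives a number 15 percentage points lower from compound 2 to compound 4 (beyond the scatter) and so moves the number beyond the scatter. The earlier compounds shown here showed only what happens when one ring group is exchanged for another, whereas this step shows that a ring carbon carrying hydrogen in compound 2 is also a place where a change of a single heavy atom can be read in this toxicity measure, and that the read-out there goes down rather than staying level. Nothing among the data shown accounts for this lower number.

It remains open whether the lower number belongs to methyl itself or to any group at this place, as no chlorine atom, methoxy group, amine or longer chain appears there among the compounds shown. From the compounds shown here alone, it also remains open whether the same added methyl would lower the number in the same way on the bromo compound 1 or the nitro compound 3.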